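The source may hold more compounds than are shown below. What is called first, only, known or untested is meant among the compounds shown, and "the series" means these compounds.

Three compounds have so far been measured in a functional assay on HeLa cells (Homo sapiens) for cytotoxicity, read by MTT assay, with a stated time of 72 h; a lower number here means a stronger inhibitor, a higher number a weaker inhibitor:

compound 1 `CC(=O)N(/N=N/c1ccc(Cl)c(C(F)(F)F)c1)c1ccc(Cl)c(C(F)(F)F)c1` gives 50600 nM
compound 2 `O=C(c1ccccc1C(F)(F)F)N(/N=N/c1ccc([N+](=O)[O-])cc1Br)c1ccc([N+](=O)[O-])cc1Br` gives 13300 nM
compound 3 `O=C(c1ccccc1)N(/N=N/c1ccc([N+](=O)[O-])cc1Cl)c1ccc([N+](=O)[O-])cc1Cl` gives 590 nM

Compound 3 stands at the lowest number of the three, and both gaps to it lie well beyond the usual scatter: compound 2 sits far above it and compound 1 further still. Since compound 3 differs from each of the other two in more than one place, nothing can be said about which part of those differences drives the gaps; the numbers alone show that compound 3 is the strongest inhibitor of the three in this assay.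

The next compound to be examined is compound 4 `O=C(c1ccc(C(F)(F)F)cc1)N(/N=N/c1ccc([N+](=O)[O-])cc1Cl)c1ccc([N+](=O)[O-])cc1Cl`. It keeps the shared core of compound 3 and changes only the benzoyl part: trifluoromethyl in place of hydrogen on an aromatic carbon. The aromatic ring on the amide carbonyl thus becomes a 4-(trifluoromethyl)phenyl group, everything else staying as in compound 3.

Within the data shown here, no comparable single step is available among the measured compounds, so the direction of the change cannot be read from them. For compound 4 a modest weakening, of a size only a little beyond the scatter, is expected, the step of a 1.7-fold higher number from compound 3 to compound 4 (0.23 log units; within the scatter). Compound 4 is therefore estimated at 1000 nM, with a range from 300 nM to 4000 nM.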

Compound 4, half-maximal inhibitory concentration: 1060 nM
Beside the measured number, compound 4's estimate is 1.1-fold (0.03 log units) below it; low and high end bracket the measured number.
By their numbers in this assay, from the lowest: compounds 3 and 4 (each within the scatter of the next); then compound 2; then compound 1.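

In this assay, among these compounds, the first comparison that differs in only one place reads a 1.8-fold higher number from compound 3 to compound 4 (0.25 log units; within the scatter). Replacing phenyl with 4-(trifluoromethyl)phenyl on the amide carbonyl therefore produces no difference that can be separated from ordinary repeat variation, so this aromatic carbon, para to a large group, can carry trifluoromethyl in place of hydrogen with the cell-based result staying within the scatter. No accompanying measurement bears on what lies behind this result.

This is a single substitution at a single position, so it does not show that other groups would be accommodated there as well: an amine, a carboxylic acid or a longer chain on the same carbon could give a very different number. It also leaves open whether trifluoromethyl would give a similar result on another carbon of this ring, or whether the same replacement would behave in the same way with different substituents on the two rings attached to the nitrogen atoms of the shared core.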